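A few compounds are considered here, and "the series" means these few. Any claim that something is new, unique, unknown or untested is made for them only; others in the source may bear on it.

Measured so far in an ADME assay on PC-3 cells (Homo sapiens) for cytotoxicity, read by WST assay, tested at 100 uM; on this read-out higher numbers stand for more inhibition at the one concentration tested (going by the name of the read-out) and lower numbers for less inhibition: compound 1 `CS(=O)(=O)Nc1cccc(C(=O)N2CCCC(C(=O)Nc3ccc(Cl)cc3)C2)c1` gives 3%; compound 2 `O=C(Nc1cccc(CN2CCCC2)c1)C1CCCN(C(=O)c2cc(C(F)(F)F)cc(C(F)(F)F)c2)C1` gives 51%; compound 3 `O=C(Nc1cccc(Oc2ccccc2)c1)C1CCCN(C(=O)c2cc(C(F)(F)F)cc(C(F)(F)F)c2)C1` gives 1%.

Of these three numbers compound 1 stands second highest. Its nearest neighbour is compound 3, whose number is within the scatter of that of compound 1, while compound 2 lies beyond the scatter above both. Compound 4 `COc1cccc(C(=O)N2CCCC(C(=O)Nc3ccc(Cl)cc3)C2)c1` is not yet measured. It differs from compound 1 in one place: methoxy in place of methanesulfonamido on an aromatic carbon. Among the measured compounds shown here, the only measured step, a number 50 percentage points lower from compound 2 to compound 3 (beyond the scatter), concerns a different group elsewhere in the shared core, so no measured step bears directly on this change. The step expected in this assay is therefore none beyond the scatter: a number 2 percentage points higher from compound 1 to compound 4 (within the scatter). Compound 4 is estimated to give 5%, with a range from -5% to 20%.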

Compound 4, a percentage reported as inhibition, at one concentration (the size of the read-out at that concentration, not a potency): 0%
For compound 4 the middle estimate is 5 percentage points above the measured one, and the stated range covers the measured number.
By their numbers in this assay, from the lowest: compounds 4, 3 and 1 (each within the scatter of the next); then compound 2.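

Methoxy in place of methanesulfonamido on this aromatic carbon gives a number 3 percentage points lower from compound 1 to compound 4 (within the scatter) in this assay and is the first measured change at this position. The group can therefore shrink and lose its hydrogen-bond donor without a change in the number that stands beyond the scatter. No measurement here offers an explanation for this result.

On these data alone, whether an amine or a carboxylic acid on this carbon would give a higher number remains open. So does whether the same exchange would behave alike on a different core.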